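The source may report more compounds than this note shows. Statements on the series, on what has been measured and on what is new or still open speak of the compounds shown alone.

Values in an ADME assay on BJ cells (Homo sapiens) for cytotoxicity, with a stated time of 72 h; on this read-out higher numbers stand for an effect only at larger amounts of compound and lower numbers for an effect already at smaller amounts:
- compound 1 `COc1ccc(-c2nc3c(c(C)nn3-c3ccccc3)c(-c3ccccc3O)c2C#N)cc1`: > 23000 nM, a limit
- compound 2 `Cc1nn(-c2ccccc2)c2nc(-c3ccc(F)cc3)c(C#N)c(-c3ccccc3O)c12`: > 20000 nM, a limit
- compound 3 `Cc1nn(-c2ccccc2)c2nc(-c3ccc(I)cc3)c(C#N)c(-c3ccccc3O)c12`: 19000 nM

For the measured compounds named here, compound 3 holds the only actual number in this set, as the other two entries are limits, so it cannot be ranked firmly against either.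

The next compound is compound 4 `Cc1nn(-c2ccccc2)c2nc(-c3ccc(S(C)(=O)=O)cc3)c(C#N)c(-c3ccccc3O)c12`, which has methylsulfonyl in place of iodo on an aromatic carbon, para to a large group: methylsulfonyl in place of iodo on an aromatic carbon.

Three measured steps exchange the group at this place. Going by the values given here, the first is a step that the two limits leave unreadable from compound 1 to compound 2. The second is an at least 1.2-fold lower number from compound 1 to compound 3 (0.08 log units; that floor lies within the scatter). The third is an at least 1.0-fold lower number from compound 2 to compound 3 (0.02 log units; that floor lies within the scatter). None of them shows a change beyond the scatter, although the limits leave their true sizes open. Methoxy, fluoro and iodo thus give no readable trend, and methylsulfonyl itself has not yet been measured in this series. No step beyond the scatter is therefore expected in this assay.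

The expected step is a 1.2-fold higher number from compound 3 to compound 4 (0.06 log units; within the scatter), with no direction expected beyond the scatter. For compound 4 the estimated value is 22000 nM. The expected range for compound 4 runs from 11000 nM to 40000 nM. A report of only a limit is expected to be slightly more likely than a number.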

Compound 4, half-maximal effective concentration: > 20000 nM
Compound 4: a limit, no number; the forecaster's own chance of this, stated with the estimate: 55%; the middle value lies beyond the limit too.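

In this assay, as far as these compounds go, methylsulfonyl in place of iodo gives an at least 1.0-fold higher number from compound 3 to compound 4 (0.02 log units; that floor lies within the scatter), so only a floor is available for this step and its true size stays open. The steps to compound 4 from compound 1 and from compound 2 cannot be read, as limits stand at both ends. New at this place is that methylsulfonyl, with four heavy atoms against one for iodo and with two hydrogen-bond acceptors, joins methoxy and fluoro in being reported only as a limit, which leaves compound 3 as the one entry with a number, and the same limit now recurs: the limit of > 20000 nM in this assay, at which 2 of the 4 values shown sit.

Still open, from the compounds shown here alone, is whether any group at this place on the phenyl ring gives a number clearly apart from that of compound 3, which an amine or a carboxylic acid there could test. Going by these compounds, all four compounds also keep the rest of the shared core unchanged, so the effect on this read-out of a change elsewhere, such as an amide in place of the nitrile, remains unknown.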